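Carbamate to Sulfamide on a Shared Core

A few compounds are considered here, and "the series" means these few. Any claim that something is new, unique, unknown or untested is made for them only; others in the source may bear on it.

For the measured compounds named here, compound 2 `COC(=O)NC[C@@H]1CCCc2cc(S(=O)(=O)c3cccc(F)c3)ccc21` is one of two compounds measured in an assay on isolated protein for displacement of a labelled ligand from 5-hydroxytryptamine receptor 6 (Homo sapiens) (a higher number here means a weaker inhibitor, a lower number a stronger inhibitor), where compound 2 gives 1.59 nM. That is the higher of the two numbers: compound 1 `N=C(N)NC(=O)C[C@@H]1CCCc2cc(S(=O)(=O)c3cccc(F)c3)ccc21` gives 0.631 nM in this assay, and the step of a 2.5-fold higher number from compound 1 to compound 2 (0.40 log units; beyond the scatter) separates them. Compound 3 `NS(=O)(=O)NC[C@@H]1CCCc2cc(S(=O)(=O)c3cccc(F)c3)ccc21` has not yet been measured. It differs from compound 2 by sulfamoyl in place of methoxycarbonyl on an amine nitrogen. Going by the values given here, the only measured step, a 2.5-fold higher number from compound 1 to compound 2 (0.40 log units; beyond the scatter), concerns the same side chain on the same core and shows that exchanging this group moves the number modestly. Among the compounds with values here, no measured step involves a sulfamoyl group, so the direction remains open. A small step of a 1.3-fold lower number from compound 2 to compound 3 (0.12 log units; within the scatter) is therefore expected, likely within the scatter. For compound 3 the estimated value is 1.2 nM, with a range from 0.4 nM to 4 nM.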

Compound 3, inhibition constant: 0.126 nM
For compound 3 the middle estimate is 9.5-fold (0.98 log units) above the measured one, outside the stated range (below it).
By their numbers in this assay, from the lowest: compound 3; then compound 1; then compound 2.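

In this assay, for the compounds shown here, this side chain proves more sensitive than the one earlier step suggested: on the amine nitrogen, sulfamoyl in place of methoxycarbonyl gives a large change (a 13-fold lower number from compound 2 to compound 3 (1.10 log units; beyond the scatter)). The sulfamoyl compound also goes past the group carried by compound 1 (a 5.0-fold lower number from compound 1 to compound 3 (0.70 log units; beyond the scatter)), so compound 3 now holds the lowest number of the three, with both of its steps beyond the scatter. No measurement offered here accounts for this gain.

The compounds shown cannot separate the contribution of the sulfonyl part of the new group from that of its terminal amino group, as they include neither a methanesulfonyl group nor a methylated sulfamoyl group on this nitrogen. They also leave open whether the sulfamoyl group would keep so low a number on a longer chain.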